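The source may hold more compounds than are shown below. What is called first, only, known or untested is meant among the compounds shown, and "the series" means these compounds.

Compound 1 `Cc1ccc(NC2=CC(=O)c3c(nc4n3[C@H]3OC[C@@H](O)[C@H]3OC4)C2=O)cc1` gives > 4000 nM in a functional assay on MCF7 cells (Homo sapiens) for inhibition, read by sulforhodamine B assay (a higher number here means a weaker inhibitor, a lower number a stronger inhibitor), a limit of the assay. Compound 2 `O=C1C=C(NC2CCCCC2)C(=O)c2c1nc1n2[C@H]2OC[C@@H](O)[C@H]2OC1` gives > 8000 nM in this assay, also a limit. Compound 3 `O=C1C=C(Nc2ccc(I)cc2)C(=O)c2c1nc1n2[C@H]2OC[C@@H](O)[C@H]2OC1` gives 2230 nM in this assay.

Compound 1 thus stands at a limit; only compound 3 has a number. Compound 4 `O=C1C(Nc2cccc(Cl)c2)=CC(=O)c2c1nc1n2[C@H]2OC[C@@H](O)[C@H]2OC1` differs from compound 1 by 3-chlorophenyl in place of 4-methylphenyl on an amine nitrogen. Going by the values given here, no measured step exchanges one aryl group for another. Among the compounds with values here, the single measured step, an at least 3.5-fold lower number from compound 2 to compound 3 (0.55 log units; beyond the scatter), put 4-iodophenyl in place of cyclohexyl and gave a lower number; compound 3, which carries 4-iodophenyl, is the one compound with a value. Compound 4 is therefore expected to land at or somewhat under the limit of compound 1, with an at least 1.3-fold lower number from compound 1 to compound 4 (0.12 log units; that floor lies within the scatter) as the expected step. Compound 4 is estimated at 3000 nM, with a range from 1000 nM to 10000 nM.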

Compound 4, half-maximal inhibitory concentration: 2970 nM
Estimate against measurement, compound 4: 1.0-fold (0.00 log units) above, within the range that was stated.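

Exchanging 4-methylphenyl for 3-chlorophenyl on this amine nitrogen gives, in this assay, an at least 1.3-fold lower number from compound 1 to compound 4 (0.12 log units; that floor lies within the scatter), the only step shown from one aryl group to another. With it, compound 4 at 2970 nM joins compound 3 at 2230 nM as a second aryl compound with a measured number. The true size of the step cannot be read because compound 1 stands at a limit: the limit of > 4000 nM in this assay, at which 1 of the 4 values shown sits.

The compounds shown leave open how 4-chlorophenyl would read at this nitrogen. They also leave open what a phenyl ring carrying a methoxy group or a carboxylic acid would give.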